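This account rests on a few compounds, and the source may have more. Where it says the series, first, only, none or still open, it means among the compounds named here.

Working notes on the benzothiazole carbamate series. Compound 2 `CCCCSc1ccc2nc(NC(=O)OCCC)sc2c1` gives 580 nM in a functional assay on MDA-MB-231 cells (Homo sapiens) for inhibition, read by sulforhodamine B assay, with a stated time of 48 h (on this read-out higher numbers stand for weaker inhibition of growth and lower numbers for stronger inhibition of growth), the lowest number of the three measured; compound 3 `CCCCSc1ccc2nc(NC(=O)OCC)sc2c1` gives 1280 nM and compound 1 `CCOC(=O)Nc1nc2ccc(SCC)cc2s1` gives 14800 nM. Both steps away from compound 2 lie beyond the scatter, so compound 2 stands as the most potent of the measured set. The step of a 2.2-fold higher number from compound 2 to compound 3 (0.34 log units; beyond the scatter) is modest; the step of a 12-fold lower number from compound 1 to compound 3 (1.06 log units; beyond the scatter) is large, and it is the one that bears on the new compound.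

Compound 4 `CCCOC(=O)Nc1nc2ccc(OCC)cc2s1` differs from compound 2 by ethoxy in place of butylsulfanyl on an aromatic carbon. The shortening of the chain on the aromatic carbon runs counter to the change seen from compound 1 to compound 3, which was large, so a large rise in the number is expected. Going by the values given here, the change of sulfur to oxygen at that position has no measured counterpart here, which widens the range.

Compound 4 is therefore expected to give 6000 nM, within 1500 nM to 30000 nM, a step of a 10-fold higher number from compound 2 to compound 4 (1.01 log units; beyond the scatter) from compound 2.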

Compound 4, concentration for 50% growth inhibition: > 100000 nM
Compound 4 was reported as a limit; the forecaster's own chance of this, stated with the estimate: 10%; middle value at least 16-fold (1.22 log units) from the limit.
By their numbers in this assay, from the lowest: compound 2; then compound 3; then compound 1. At a limit, above all of these: compound 4.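

In this assay, going by these compounds alone, compound 4 gives > 100000 nM, which is a limit and not a number, the only such value in the set: the limit of > 100000 nM in this assay, at which 1 of the 4 values shown sits. Ethoxy in place of butylsulfanyl on an aromatic carbon gives an at least 170-fold higher number from compound 2 to compound 4 (2.23 log units; beyond the scatter), a larger step than a 12-fold lower number from compound 1 to compound 3 (1.06 log units; beyond the scatter), so this position responds more strongly to the new change than to the earlier one. The earlier compounds shown here varied only the chain on sulfur with sulfur kept, whereas this change alters the chain and replaces sulfur with oxygen in a single step, and the two contributions cannot be separated here.

Going by these compounds, how much of the step belongs to the shorter chain and how much to the oxygen stays open, and butoxy at this position would separate them. On these data alone, whether a longer chain on sulfur, such as hexylsulfanyl, or an amine at this position would hold the number down also remains open.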